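From Hydroxy to Methoxy, Made a Second Time

The source may hold more compounds than are shown below. What is called first, only, known or untested is meant among the compounds shown, and "the series" means these compounds.

Compound 1 `O=C(Nc1cccc(-n2cc(-c3ccncc3)c(-c3cc(O)cc(Cl)c3)n2)c1)Nc1ccc(Cl)c(Cl)c1` and compound 2 `COc1cc(Cl)cc(-c2nn(-c3cccc(NC(=O)Nc4ccc(Cl)c(Cl)c4)c3)cc2-c2ccncc2)c1` share one core and differ in a single place: methyl in place of hydrogen on an oxygen on an aromatic ring. In a functional assay on SN12C cells (Homo sapiens) for inhibition, read by sulforhodamine B assay, with a stated time of 48 h, tested at 10 uM (on this read-out lower numbers stand for a stronger effect and higher numbers for a weaker effect at the one concentration tested), compound 1 gives 14.9%, and in this assay compound 2 gives 15.5%. The change therefore left the read-out essentially where it was, as the step of a number 0.6 percentage points higher from compound 1 to compound 2 (within the scatter) shows; the two numbers cannot be told apart.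

Compound 3 `O=C(Nc1cccc(-n2cc(-c3ccncc3)c(-c3cc(O)cc(Cl)c3)n2)c1)c1cc(C(F)(F)F)cc(C(F)(F)F)c1` is built on another core. How the cores of compound 1 and compound 3 differ is not broken down here. In this assay compound 3 gives 50.3%, the highest of the three numbers, with the nearest of the other two more than the scatter away, so its effect at the single concentration is clearly weaker than that of compound 1 or compound 2.

Compound 4 `COc1cc(Cl)cc(-c2nn(-c3cccc(NC(=O)c4cc(C(F)(F)F)cc(C(F)(F)F)c4)c3)cc2-c2ccncc2)c1` has not yet been measured in this assay. It differs from compound 3 by methyl in place of hydrogen on an oxygen on an aromatic ring, which is the same change, at the same kind of place, that turns compound 1 into compound 2. Because the step of a number 0.6 percentage points higher from compound 1 to compound 2 (within the scatter) lay within the scatter, the corresponding step of a number 0.7 percentage points higher from compound 3 to compound 4 (within the scatter) is expected to be just as small. On that basis compound 4 is estimated to give 51% in this assay, most likely falling between 38% and 64%.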

Compound 4, a percentage reported as activity, at one concentration (the size of the read-out at that concentration, not a potency): 69.8%
Beside the measured number, compound 4's estimate is 18.8 percentage points below it, and the stated range ends below it.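

Carried from the core of compound 1 to the core of compound 3, the change from hydroxy to methoxy did not leave the read-out in place: in this assay it gave a number 19.5 percentage points higher from compound 3 to compound 4 (beyond the scatter), a clear weakening of the effect at the one concentration tested. The two steps therefore differ, and the change does not transfer unaltered between these two cores: the same change on two cores in this assay, a number 0.6 percentage points higher (within the scatter) from compound 1 to compound 2 and a number 19.5 percentage points higher (beyond the scatter) from compound 3 to compound 4, 18.9 percentage points apart, beyond the scatter of two such steps. This shows that, in these two pairs, the result of the methylation depends on the core that carries it, so a flat step on one core is no safe guide to the other; it does not show which feature of the cores is responsible, and two pairs at a single concentration support no general rule for the series.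

The compounds shown leave open how an amine or a longer chain such as ethoxy in place of hydroxy would read in this assay on either core. They also leave open whether a further core would follow the flat step or the larger one, and whether the gap between the two steps would hold at other concentrations.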